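Replacing the hydroxy group of compound 2: working notes

This account rests on a few compounds, and the source may have more. Where it says the series, first, only, none or still open, it means among the compounds named here.

Compound 1 `COCc1cc(CCCOc2c(C)cc(-c3noc(C(F)(F)F)n3)cc2C)on1`: 1.58 h
Compound 2 `Cc1cc(-c2noc(C(F)(F)F)n2)cc(C)c1OCCCc1cc(CO)no1`: > 2.5 h

Both values come from an in vitro ADME assay on microsomes from liver (Simiiformes); a lower number here means that the compound disappears faster, a higher number that the compound lasts longer. Compound 2 reads > 2.5 h, which is a limit of the assay and not a number. That places compound 2 at the limit of > 2.5 h in this assay, at which 1 of the 2 values shown sits.

Compound 3 `Cc1cc(-c2noc(C(F)(F)F)n2)cc(C)c1OCCCc1cc(C[S+](C)[O-])no1` changes the hydroxy of compound 2, on a saturated chain carbon bound to an aromatic carbon: a group of 3 heavy atoms (1 carbon, 1 oxygen, 1 sulfur; no ring) in place of one oxygen atom, on a saturated chain carbon bound to an aromatic carbon. For the measured compounds named here, the entering group has no measured precedent. Going by the values given here, the one measured step at this place, hydrogen in place of methyl on an oxygen, is an at least 1.5-fold higher number from compound 1 to compound 2 (0.19 log units; that floor lies within the scatter). Because of an at least 1.5-fold higher number from compound 1 to compound 2 (0.19 log units; that floor lies within the scatter) no change beyond the scatter is expected, and any drift would more likely be downward from the limit.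

The step expected in this assay is an at least 1.0-fold lower number from compound 2 to compound 3 (0.03 log units; that floor lies within the scatter). For compound 3 the estimated half-life is 2.3 h, with an expected range of 1.2 h to 4 h.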

Compound 3, half-life: > 2.5 h
Compound 3: no number, only a limit (the forecaster's own chance of this, stated with the estimate: 40%); middle value at least 1.0-fold (0.03 log units) from the limit.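

In this assay compound 3 gives > 2.5 h, which is a limit of the assay and not a number. The entering group has 0 hydrogen-bond donors, so the hydroxy of compound 2 is not required at this place for a compound to reach the limit, and the comparison with the earlier methyl ether gives an at least 1.5-fold higher number from compound 1 to compound 3 (0.19 log units; that floor lies within the scatter). The step between compound 2 and compound 3 cannot be read, and the position now stands as follows: the limit of > 2.5 h in this assay, at which 2 of the 3 values shown sit.

On these data alone, how far compound 2 and compound 3 lie beyond the limit stays open, so no order between them can be given. Also open, as far as these compounds go, is whether an amine, a carboxylic acid or a longer chain on this saturated chain carbon would reach the same limit.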